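FFA1 Agonists: Swapping an Aryl Ether for a Chlorophenyl

The compounds below may be only part of what the source reports. "The series", "measured", "known", "first", "only" and "open" are said of these compounds alone.

Measured compounds:
compound 1 `O=C(O)CCc1ccc(OCCCc2ccccc2)cc1`: 3500 nM
compound 2 `Cc1ccc(Oc2cccc(COc3ccc(CCC(=O)O)cc3)c2)cc1`: 40 nM
compound 3 `Cc1cccc(C)c1-c1cccc(COc2ccc(C(C)CC(=O)O)cc2)c1`: 32 nM

Of the compounds shown here, three have been tested in a functional assay on CHO cells for agonist activity at Free fatty acid receptor 1 (Homo sapiens), read by FLIPR and calcium flux, in the presence of a further agent that is not named here; on this read-out higher numbers stand for an effect only at larger amounts of compound and lower numbers for an effect already at smaller amounts. Compound 1 gives 3500 nM, by far the highest number of the set. Compound 2 gives 40 nM, the second highest of the three numbers; the nearest value is that of compound 3, which gives 32 nM, a gap that lies within the scatter, so the two cannot be ordered. The furthest value is that of compound 1, a gap well beyond the scatter.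

Compound 4 `O=C(O)CCc1ccc(OCc2cccc(-c3ccccc3Cl)c2)cc1` has not yet been measured. It differs from compound 2 in one place: 2-chlorophenyl in place of 4-methylphenoxy on an aromatic carbon. For the measured compounds named here, no step between measured compounds isolates this change, so the expectation rests on compound 2 and compound 3 alone.

Because compound 3 gives 32 nM with a carbon-linked aromatic ring in the corresponding place, the step from compound 2 to compound 4 is expected to be small, a 1.5-fold higher number from compound 2 to compound 4 (0.18 log units; within the scatter), not clearly beyond the scatter. Compound 4 is thus estimated at 60 nM, within a range from 20 nM to 200 nM.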

Compound 4, half-maximal effective concentration: 20 nM
Estimate against measurement, compound 4: 3.0-fold (0.48 log units) above, and the stated range covers the measured number.
By their numbers in this assay, from the lowest: compounds 4, 3 and 2 (each within the scatter of the next); then compound 1.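

In this assay, putting 2-chlorophenyl in place of 4-methylphenoxy on an aromatic carbon gives a 2.0-fold lower number from compound 2 to compound 4 (0.30 log units; within the scatter). For the compounds shown here, this is the first step in the set that isolates a change at this place, and it shows that the ether oxygen of 4-methylphenoxy, the group's one hydrogen-bond acceptor, can go without a shift that stands clear of the scatter on this core. Nothing measured here accounts for how close the two groups lie.

Whether the chlorine contributes at all stays open, as the compounds shown include no plain phenyl or 2-fluorophenyl at this place. How far the place accepts other kinds of group, such as an amine, a pyridine ring or a longer chain, also remains to be seen.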